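The source may hold more compounds than are shown below. What is called first, only, known or untested is meant among the compounds shown, and "the series" means these compounds.

Measured compounds:
- compound 1, `CCn1c(C(=O)NCCN(C)C)ccc1C(CC)(CC)c1ccc(OCCC(O)(CC)CC)c(C)c1`: 870 nM
- compound 2, `CCn1c(C(=O)NCC#N)ccc1C(CC)(CC)c1ccc(OCCC(O)(CC)CC)c(C)c1`: 17800 nM
- compound 3, `CCn1c(C(=O)Nc2ccc(OC(F)(F)F)cc2)ccc1C(CC)(CC)c1ccc(OCCC(O)(CC)CC)c(C)c1`: > 50000 nM

All three share one core and differ only in the group on the amide-type nitrogen. In a functional assay on PC-3 cells (Homo sapiens) for antiproliferative activity, read by MTT assay, with a stated time of 48 h (a higher number here means a weaker inhibitor, a lower number a stronger inhibitor), compound 1 gives 870 nM. Compound 2 gives 17800 nM, a 20-fold higher number from compound 1 to compound 2 (1.31 log units; beyond the scatter). Compound 3 reaches only the limit of this assay, > 50000 nM, so for compound 3 no number is known (the limit of > 50000 nM in this assay, at which 1 of the 3 values shown sits). Against compound 1 that is an at least 57-fold higher number from compound 1 to compound 3 (1.75 log units; beyond the scatter), and against compound 2 it is an at least 2.8-fold higher number from compound 2 to compound 3 (0.44 log units; beyond the scatter); compound 3 thus stands weakest of the three.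

Compound 4, `CCn1c(C(=O)NC(C)CO)ccc1C(CC)(CC)c1ccc(OCCC(O)(CC)CC)c(C)c1`, carries the change (1-(hydroxymethyl)ethyl in place of 4-(trifluoromethoxy)phenyl on an amide-type nitrogen). Going by the values given here, the steps that bear on it are the two leading into compound 3: both replacements of a saturated chain on the amide nitrogen by the aryl group raised the number, and the smaller, neutral chain of compound 2 sat far from compound 1. Compound 4 is expected to come back off the limit, nearer compound 2 than compound 1, as an estimated at least 3.3-fold lower number from compound 3 to compound 4 (0.52 log units; beyond the scatter). Compound 4 is therefore expected at about 15000 nM, between 4000 nM and 50000 nM.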

Compound 4, half-maximal inhibitory concentration: 7870 nM
Compound 4: the middle estimate sits 1.9-fold (0.28 log units) above what was measured; the range from low to high includes it.
By their numbers in this assay, from the lowest: compound 1; then compound 4; then compound 2. At a limit, above all of these: compound 3.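

In this assay, putting 1-(hydroxymethyl)ethyl in place of 4-(trifluoromethoxy)phenyl on the amide-type nitrogen brings the series back to a measurable value, with an at least 6.3-fold lower number from compound 3 to compound 4 (0.80 log units; beyond the scatter). The size of that step is only a bound, as one end of it is a limit: the limit of > 50000 nM in this assay, at which 1 of the 4 values shown sits. The new chain also gives a 2.3-fold lower number from compound 2 to compound 4 (0.35 log units; beyond the scatter), yet falls short of the 2-(dimethylamino)ethyl group, with a 9.0-fold higher number from compound 1 to compound 4 (0.96 log units; beyond the scatter), so this position separates the saturated chains from one another and not only from the aryl group.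

The compounds shown leave open whether the lead of compound 1 depends on its dimethylamino group, which a primary amine, a morpholine or a carboxylic acid on the same chain would test. They also leave open whether the hydroxyl or the branching of compound 4 matters more, which a straight 2-hydroxyethyl chain would help to separate.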